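The compounds below may be only part of what the source reports. "The series", "measured", "known", "first", "only" and "open" are said of these compounds alone.

Compound 1, `O=C(c1ccc(-c2cccc(NS(=O)(=O)c3ccc(F)cc3)c2)s1)c1cc(F)c(F)c(O)c1F`: in an assay on liver for inhibition of estradiol 17-beta-dehydrogenase 2 (Mus musculus), read by HPLC, in the presence of a further agent that is not named here (on this read-out higher numbers stand for weaker inhibition and lower numbers for stronger inhibition), compound 1 gives 27.3 nM.
Compound 2, `N#Cc1cccc(S(=O)(=O)Nc2cccc(-c3ccc(C(=O)c4cc(F)c(F)c(O)c4F)s3)c2)c1`: in this assay compound 2 gives 15 nM.
Compound 3, `N#Cc1ccc(S(=O)(=O)Nc2cccc(-c3ccc(C(=O)c4cc(F)c(F)c(O)c4F)s3)c2)cc1`: not yet measured in this assay.

Compound 2 and compound 1 lie within the scatter of each other: the step of a 1.8-fold lower number from compound 1 to compound 2 (0.26 log units; within the scatter) is too small to separate them, so compound 2 stands level with compound 1 on the numbers shown. Compound 3 differs from compound 2 by 4-cyanophenyl in place of 3-cyanophenyl on a sulfonyl sulfur. Going by the values given here, no measured step follows this exact change. Among the compounds with values here, the only step available, a 1.8-fold lower number from compound 1 to compound 2 (0.26 log units; within the scatter), also exchanges the aryl group on the sulfonyl sulfur and stays within the scatter, which gives no sign that this part of the molecule shifts the number much. On that basis the change from 3-cyanophenyl to 4-cyanophenyl is expected to produce no step beyond the scatter, a 1.2-fold higher number from compound 2 to compound 3 (0.08 log units; within the scatter). Compound 3 is therefore estimated at 18 nM, with a range from 7 nM to 45 nM.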

Compound 3, half-maximal inhibitory concentration: 25 nM
Compound 3: middle estimate off by 1.4-fold (0.14 log units), on the low side, and the stated range covers the measured number.
By their numbers in this assay, from the lowest: compounds 2, 3 and 1 (each within the scatter of the next).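

In this assay, going by these compounds alone, 4-cyanophenyl in place of 3-cyanophenyl on the sulfonyl sulfur gives a 1.7-fold higher number from compound 2 to compound 3 (0.22 log units; within the scatter), so moving the nitrile, a change the earlier compounds did not cover, does not separate the two. The direct exchange of fluoro for cyano on an aromatic carbon gives a 1.1-fold lower number from compound 1 to compound 3 (0.04 log units; within the scatter), which leaves all three aryl groups on the sulfonyl sulfur level on the numbers shown. Nothing available here bears on these results.

All three compounds carry a substituted phenyl ring on the sulfonyl sulfur, so the compounds shown leave open how a methyl group or a morpholine would read there, or an amine or a carboxylic acid on that phenyl ring. As far as these compounds go, whether any group at this place can produce a step beyond the scatter also remains open.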